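Half-life notes: from compound 1 to compound 3

The source may report more compounds than this note shows. Statements on the series, on what has been measured and on what is new or still open speak of the compounds shown alone.

Measured in an ADME assay on microsomes from liver (Homo sapiens) for metabolic stability (a lower number here means that the compound disappears faster, a higher number that the compound lasts longer), so far:
Compound 1 (`CC(C)C(/C=C1\NC(=O)NC1=O)c1ccc(-c2ccc3cccc(F)c3c2)[nH]c1=O`): half-life (> 3 h), a limit and not a number
Compound 2 (`CCc1cccc2ccc(-c3ccc(C(/C=C4\OC(=O)NC4=O)(CC)CC)c(=O)[nH]3)cc12`): half-life (0.178 h)

Compound 1 has no exact number and stands only at a limit (the limit of > 3 h in this assay, at which 1 of the 2 values shown sits). It therefore gives a lower bound for the comparison and not a fixed starting value.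

Compound 3 (`CC(C)C(CC1C(=O)NC(=O)N1C)c1ccc(-c2ccc3cccc(F)c3c2)[nH]c1=O`) keeps the shared core of compound 1. The change sits on a saturated chain carbon bound to an aromatic carbon and a saturated chain carbon, where (3-methyl-2,5-dioxoimidazolidin-4-yl)methyl enters (a group of 9 heavy atoms (5 carbon, 2 nitrogen, 2 oxygen; one five-membered non-aromatic ring with 2 hetero atoms) in place of a group of 8 heavy atoms (4 carbon, 2 nitrogen, 2 oxygen; one five-membered non-aromatic ring with 2 hetero atoms), on a saturated chain carbon bound to an aromatic carbon and a saturated chain carbon).

Going by the values given here, no measured pair covers this change, so the expectation is loose. Compound 2 (0.178 h) shows that short half-lives do occur in the series, and this leans the expectation downward. A modest downward step is expected (an at least 1.2-fold lower number from compound 1 to compound 3 (0.07 log units; that floor lies within the scatter)), and a result that stays at the limit of the assay would not be surprising. For compound 3 the estimated half-life is 2.5 h (expected range 0.7 h to 6 h).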

Compound 3, half-life: 0.153 h
Estimate against measurement, compound 3: 16-fold (1.21 log units) above, and the stated range ends above it.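

In this assay compound 1 gives > 3 h, which is a limit and not a number. Going by these compounds alone, with the shared core held, placing (3-methyl-2,5-dioxoimidazolidin-4-yl)methyl on the saturated chain carbon bound to an aromatic carbon and a saturated chain carbon gives an at least 19-fold lower number from compound 1 to compound 3 (1.29 log units; beyond the scatter), and the true size of this step is bounded from one side only: the limit of > 3 h in this assay, at which 1 of the 3 values shown sits. This is the first reading at this position, and it shows that the half-life in this assay is highly sensitive to this exchange of one five-membered non-aromatic ring group for another, with compound 3 at 0.153 h.

The entering group differs from the leaving one at once in heavy atoms, in double bonds outside aromatic rings and in hydrogen-bond donors, so the compounds shown leave open which of these differences, or the methyl of the entering group alone, carries the step. Also open, going by these compounds, is how the half-life would respond to a simple amine, a carboxylic acid or a longer chain on the same saturated chain carbon.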